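Trimming the Piperazine: Dimethylamino at the Core

The compounds below may be only part of what the source reports. "The series", "measured", "known", "first", "only" and "open" are said of these compounds alone.

Three measured compounds share a bicyclic core bearing an aromatic amine side chain and a fluorophenyl amide. Compound 1 `Cc1ccc2nc(N3CCNC(C)C3)nc(NCc3ccc(C(=O)NCc4ccc(F)cc4)cc3)c2c1` gives 2900 nM in a functional assay on HCT-116 cells (Homo sapiens) for inhibition, read by luminescence and resazurin assay, with a stated time of 3 days (on this read-out higher numbers stand for weaker inhibition and lower numbers for stronger inhibition), the lowest of the two numbers recorded. Compound 2 `CN(C)CCCNc1nc(NCc2ccc(NC(=O)c3ccc(F)cc3)cc2)c2ccccc2n1` gives 10000 nM in this assay, a higher number that lies beyond the scatter of compound 1. Compound 3 `CNc1nc2ccccc2c(NCc2ccc(NC(=O)c3ccc(F)cc3)cc2)c1C#N` gives > 20000 nM in this assay, which is a limit of the assay and not a number; it sits at the limit of > 20000 nM in this assay, at which 1 of the 3 values shown sits. For the measured compounds named here, no step between compounds that differ in a single place has been measured, so the three values cannot be tied to any one structural change.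

Compound 4 `Cc1ccc2nc(N(C)C)nc(NCc3ccc(C(=O)NCc4ccc(F)cc4)cc3)c2c1` has not yet been measured. It differs from compound 1 in one place: dimethylamino in place of 3-methylpiperazin-1-yl on an aromatic carbon. The large side chain, the fluorophenyl amide and the methyl on the core are unchanged.

Going by the values given here, with no measured step to lean on, the expectation rests on the removal of the ring and its donor alone. A modest loss of inhibition is expected, with the step of a 2.8-fold higher number from compound 1 to compound 4 (0.44 log units; beyond the scatter) taken as the estimate. Compound 4 is therefore estimated to give 8000 nM in this assay, with a range from 3000 nM to 25000 nM.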

Compound 4, half-maximal inhibitory concentration: 900 nM
Beside the measured number, compound 4's estimate is 8.9-fold (0.95 log units) above it; measured number outside the range, below it.
By their numbers in this assay, from the lowest: compound 4; then compound 1; then compound 2. At a limit, above all of these: compound 3.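

For the compounds shown here, this is the first step that can be read at a single place. In this assay, putting dimethylamino in place of 3-methylpiperazin-1-yl on the aromatic carbon between two ring nitrogen atoms gives a 3.2-fold lower number from compound 1 to compound 4 (0.51 log units; beyond the scatter), so the smaller group goes with stronger inhibition here. At this position, then, neither the six-membered non-aromatic ring nor its hydrogen-bond donor is needed for inhibition at the level of compound 1, and nothing among the measurements offered here explains why the change has this effect.

The compounds shown leave open whether the ring or its donor accounts for the step, a question that a piperidine or a morpholine at the same carbon, each of which keeps a six-membered ring but has no nitrogen-bound hydrogen, would help to answer. Also open, on these data alone, is whether the same change would have a similar effect on another core or side chain, as compound 2 and compound 3 each differ from compound 4 in more than one place and so offer no direct comparison.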